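The source may hold more compounds than are shown below. What is called first, only, known or untested is meant among the compounds shown, and "the series" means these compounds.

Measured compounds:
compound 1, `CCOc1ccc(C(=O)/C=C/c2ccc(C)cc2)cc1`, 210 nM
compound 2, `O=C(/C=C/c1ccc(ON=C(c2ccccc2)c2ccccc2)cc1)c1ccc(F)cc1`, < 50 nM
compound 3, `O=C(/C=C/c1ccc(C(F)(F)F)cc1)c1ccc(-n2ccnc2)cc1`, > 10000 nM

Within the data shown here, in an assay on isolated protein for inhibition of Amine oxidase [flavin-containing] B (Homo sapiens) (on this read-out higher numbers stand for weaker inhibition and lower numbers for stronger inhibition), compound 1 is the only compound with a numerical result, a value of 210 nM. Compound 2 does not give a number in this assay but sits at the limit of < 50 nM in this assay, at which 1 of the 3 values shown sits. Compound 3 likewise gives no number and sits at the limit of > 10000 nM in this assay, at which 1 of the 3 values shown sits. Among the measured compounds shown here, no two of these three compounds differ in a single place, so no measured step is available to guide the next change.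

Compound 4, `CCOc1ccc(C(=O)/C=C/c2ccc(F)cc2)cc1`, has not yet been measured in this assay. It differs from compound 1 by fluoro in place of methyl on an aromatic carbon. Both compounds carry the shared core, and the exchanged group is a single heavy atom in each direction. For the measured compounds named here, with no measured pair to lean on, the step from compound 1 to compound 4 is expected to stay within the usual scatter, a 1.3-fold lower number from compound 1 to compound 4 (0.12 log units; within the scatter), and no direction can be claimed with confidence. Compound 4 is therefore estimated at 160 nM, with a range from 50 nM to 500 nM.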

Compound 4, half-maximal inhibitory concentration: 53 nM
Beside the measured number, compound 4's estimate is 3.0-fold (0.48 log units) above it, and the stated range covers the measured number.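

In this assay, among these compounds, the exchange of methyl for fluoro on an aromatic carbon para to a large group gives a 4.0-fold lower number from compound 1 to compound 4 (0.60 log units; beyond the scatter) and is the only step between compounds that differ in one place. It shows that this position is not indifferent to the exchange of one heavy atom for another, although neither group carries a hydrogen-bond donor or acceptor. Nothing measured here accounts for the size or direction of this step.

Going by these compounds, whether chloro, methoxy or an amine in the same place would lower the number further remains open. Also open, on these data alone, is whether the effect of fluoro in place of methyl would hold if the ethoxy group shared by compound 1 and compound 4 gave way to a longer chain.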